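The source may hold more compounds than are shown below. What is called first, only, known or untested is meant among the compounds shown, and "the series" means these compounds.

Measured in a functional assay on Jurkat cells for inhibition of nuclear factor NF-kappa-B complex (Homo sapiens); a higher number here means a weaker inhibitor, a lower number a stronger inhibitor:
compound 1 `CCOC(=O)c1cnc(-c2cnc3ccccc3c2)nc1NN1C(=O)C=C(C)C1=O` — 6000 nM
compound 2 `CCOC(=O)c1cnc(-n2nc(C)cc2C)nc1NN1C(=O)C=C(C)C1=O` — 10000 nM
compound 3 `CCOC(=O)c1cnc(-c2ccc(OC)cc2)nc1NN1C(=O)C=C(C)C1=O` — 900 nM

Compound 3 gives the lowest number of the three; the gaps a 6.7-fold lower number from compound 1 to compound 3 (0.82 log units; beyond the scatter) and an 11-fold lower number from compound 2 to compound 3 (1.05 log units; beyond the scatter) are both beyond the scatter, whereas a 1.7-fold higher number from compound 1 to compound 2 (0.22 log units; within the scatter) is within it. Compound 4 `CCOC(=O)c1cnc(-c2ccc(C)s2)nc1NN1C(=O)C=C(C)C1=O` is not yet measured; the change is 5-methylthiophen-2-yl in place of 4-methoxyphenyl on an aromatic carbon. Every measured step alters this same position, and both steps into 4-methoxyphenyl lowered the number, so the position is sensitive. Going by the values given here, no measured step involves a thiophene, so its direction is open. Leaving 4-methoxyphenyl is expected to cost some potency, and the estimate for compound 4 is 2500 nM (range 700 nM to 9000 nM), i.e. a 2.8-fold higher number from compound 3 to compound 4 (0.44 log units; beyond the scatter) is expected.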

Compound 4, half-maximal inhibitory concentration: 200 nM
Compound 4: middle estimate off by 13-fold (1.10 log units), on the high side; the whole stated range lies above it.
By their numbers in this assay, from the lowest: compound 4; then compound 3; then compounds 1 and 2 (each within the scatter of the next).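

The position accepts a five-membered aromatic ring with a sulfur atom, and 5-methylthiophen-2-yl in place of 4-methoxyphenyl gives a 4.5-fold lower number from compound 3 to compound 4 (0.65 log units; beyond the scatter), so a six-membered aromatic ring of carbon only is not needed here. The same group also gives a 50-fold lower number from compound 2 to compound 4 (1.70 log units; beyond the scatter) and a 30-fold lower number from compound 1 to compound 4 (1.48 log units; beyond the scatter), which places compound 4 lowest of the four. Nothing measured here accounts for these gains.

From the compounds shown here alone, whether the methyl matters remains open, as an unsubstituted thiophen-2-yl or a furan-2-yl would test. Also open, going by these compounds, is whether a carboxylic acid in place of the ethoxycarbonyl group would keep this level.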